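The source may hold more compounds than are shown below. What is called first, only, known or untested is meant among the compounds shown, and "the series" means these compounds.

Working notes on the series, read in a functional assay on MCF7 cells (Homo sapiens) for antiproliferative activity, read by MTT assay, with a stated time of 48 h; on this read-out higher numbers stand for weaker inhibition and lower numbers for stronger inhibition. Compound 1 (`O=C(NS(=O)(=O)c1ccccc1)c1cccnc1`) gives 14400 nM, compound 2 (`Cc1ccc(S(=O)(=O)NC(=O)c2cccnc2)cc1`) gives 12000 nM and compound 3 (`O=C(NS(=O)(=O)c1ccccc1)c1cccnc1Cl`) gives 14000 nM. These three values lie within the scatter of one another, so compound 3 cannot be separated from compound 1 or compound 2.

Compound 4 (`O=C(NS(=O)(=O)c1ccc(Br)cc1)c1cccnc1Cl`) differs from compound 3 in one place: bromo in place of hydrogen on an aromatic carbon, on the six-membered aromatic ring of carbon only, para to a large group.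

Going by the values given here, two measured steps bear on this change. The methyl step, a 1.2-fold lower number from compound 1 to compound 2 (0.08 log units; within the scatter), is the closer precedent, since it falls on the same kind of carbon, para to a large group. The chloro step, a 1.0-fold lower number from compound 1 to compound 3 (0.01 log units; within the scatter), brings in a halogen, but on a different ring. Both stayed within the scatter. Among the compounds with values here, no bromo compound has been measured, so the precedent is thin.

On this evidence, no change beyond the scatter is expected in this assay, with only a slight lean towards a lower number. The expected size of the change is a 1.4-fold lower number from compound 3 to compound 4 (0.15 log units; within the scatter). For compound 4 the estimated value is 10000 nM, with an expected range of 4000 nM to 20000 nM.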

Compound 4, half-maximal inhibitory concentration: 11400 nM
Compound 4: the middle estimate sits 1.1-fold (0.06 log units) below what was measured; low and high end bracket the measured number.
By their numbers in this assay, from the lowest: compounds 4, 2, 3 and 1 (each within the scatter of the next).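

In this assay the step of a 1.2-fold lower number from compound 3 to compound 4 (0.09 log units; within the scatter) shows that a bromo group on this aromatic carbon, para to a large group, leaves the number within the scatter of the parent. Going by these compounds alone, until now methyl was the only group read at this place, through the step of a 1.2-fold lower number from compound 1 to compound 2 (0.08 log units; within the scatter) on the core of compound 1, whereas the bromo step stands on the chlorinated core of compound 3, so two different groups on two different backgrounds now give no separable step here. Nothing at hand bears on why these numbers stay together.

Going by these compounds, it stays open whether any group at this place can move the number beyond the scatter, for example an amine or a carboxylic acid, which would differ from methyl and bromo far more than those two differ from each other. It is also open whether the bromo step would read the same on the core of compound 1 without the chloro group, since the steps shown at this place rest on one background each.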